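The source may report more compounds than this note shows. Statements on the series, on what has been measured and on what is new or still open speak of the compounds shown alone.

Compound 1 `O=C(COc1cccc2ccccc12)N/N=C/c1ccc(Cl)cc1` gives 87.6 ug/mL in an ADME assay on MT4 cells (Homo sapiens) for cytotoxicity, read by MTT assay, with a stated time of 4 days; a higher number here means that more compound is tolerated, a lower number that less compound is tolerated.
Compound 2 `O=C(COc1cccc2ccccc12)N/N=C/c1ccc(F)cc1` gives 65.1 ug/mL in this assay.
Compound 3 `COc1ccc(/C=N/NC(=O)COc2cccc3ccccc23)cc1` gives 76.9 ug/mL in this assay.

Compound 3 stands second highest of the three, but the steps to it, a 1.1-fold lower number from compound 1 to compound 3 (0.06 log units; within the scatter) and a 1.2-fold higher number from compound 2 to compound 3 (0.07 log units; within the scatter), are within the scatter, so the three compounds cannot be told apart on these numbers. Compound 4 `CSc1ccc(/C=N/NC(=O)COc2cccc3ccccc23)cc1` differs from compound 3 in one place: methylsulfanyl in place of methoxy on an aromatic carbon. For the measured compounds named here, every measured step so far swapped one group on an aromatic carbon, and all three stayed within the scatter, including a 1.3-fold lower number from compound 1 to compound 2 (0.13 log units; within the scatter). This change is of the same kind, so no step beyond the scatter is expected in this assay, that is a 1.0-fold higher number from compound 3 to compound 4 (0.00 log units; within the scatter). Compound 4 is therefore estimated at 77 ug/mL, with a range from 45 ug/mL to 130 ug/mL.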

Compound 4, half-maximal cytotoxic concentration: 68.3 ug/mL
Beside the measured number, compound 4's estimate is 1.1-fold (0.05 log units) above it, within the range that was stated.
By their numbers in this assay, from the lowest: compounds 2, 4, 3 and 1 (each within the scatter of the next).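

In this assay, methylsulfanyl in place of methoxy gives a 1.1-fold lower number from compound 3 to compound 4 (0.05 log units; within the scatter) and so adds a sulfur-bearing group to the changes at this position that stay within the scatter. Compound 4 also cannot be told apart from the halogen compounds, with a 1.0-fold higher number from compound 2 to compound 4 (0.02 log units; within the scatter) and a 1.3-fold lower number from compound 1 to compound 4 (0.11 log units; within the scatter) both within the scatter as well. No measurement at hand gives a reason for this flat result.

From the compounds shown here alone, whether an amine, a carboxylic acid or a longer chain at this position would give a step beyond the scatter stays open. So does the effect of changes elsewhere on the shared core.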